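Fluoro Gives Way to Acetamido on the Shared Core

The source may hold more compounds than are shown below. What is called first, only, known or untested is meant among the compounds shown, and "the series" means these compounds.

In an ADME assay on L02 cells (Homo sapiens) for cytotoxicity, read by MTT assay, with a stated time of 24 h (a lower number here means a stronger inhibitor, a higher number a weaker inhibitor), compound 1 (`N#Cc1ccc(/C=C2\CN(S(=O)(=O)c3ccc(F)cc3)C/C(=C\c3ccc(C#N)cc3)C2=O)cc1`) gives 18900 nM and compound 2 (`COc1cc(/C=C2\CN(S(=O)(=O)c3ccc(F)cc3)C/C(=C\c3cc(OC)c(OC)c(OC)c3)C2=O)cc(OC)c1OC`) gives 12100 nM as its number. For the measured compounds named here, the two values lie within the scatter of each other, so compound 1 does not stand apart from the only other compound measured. Compound 3 (`CC(=O)Nc1ccc(S(=O)(=O)N2C/C(=C\c3ccc(C#N)cc3)C(=O)/C(=C/c3ccc(C#N)cc3)C2)cc1`) keeps the core of compound 1 and differs from it by acetamido in place of fluoro on an aromatic carbon with acetamido in place of fluoro on an aromatic carbon, para to a large group. Compound 1 and compound 2 both carry the 4-fluorophenyl, so their numbers say nothing about this swap. Going by the values given here, with no measured pair showing the change, no step beyond the scatter is expected in this assay and no direction is favoured. The estimated move is a 1.2-fold lower number from compound 1 to compound 3 (0.07 log units; within the scatter) and no more than that. Compound 3 is expected at 16000 nM (estimated range 7000 nM to 35000 nM).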

Compound 3, half-maximal inhibitory concentration: 14000 nM
Estimate against measurement, compound 3: 1.1-fold (0.06 log units) above; measured number inside the range.
By their numbers in this assay, from the lowest: compounds 2, 3 and 1 (each within the scatter of the next).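

The change from 4-fluorophenyl to 4-acetamidophenyl now has a measured step in this assay (a 1.4-fold lower number from compound 1 to compound 3 (0.13 log units; within the scatter)), and that step lies within the scatter. On this aromatic carbon, para to a large group, acetamido with its 4 heavy atoms, hydrogen-bond donor and hydrogen-bond acceptor stands in place of a single fluorine, and the two compounds cannot be told apart by this read-out. Nothing measured here bears on why this is so.

From the compounds shown here alone, whether an amine, a carboxylic acid or a longer acyl chain at this position would give a step beyond the scatter remains open. Going by these compounds, it is also open whether acetamido in place of fluoro would give a similar step on the trimethoxyphenyl-bearing compound 2.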